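The compounds below may be only part of what the source reports. "The series", "measured", "known", "first", "only" and "open" are said of these compounds alone.

Measured so far:
compound 1 `Cc1cccc(/C(N)=N/NC(=S)N2CCCCC2)n1` — 63.2%
compound 2 `Cc1cccc(/C(N)=N/NC(=S)N2CCCC2)n1` — 51.3%
compound 3 `Cc1ccnc(/C(N)=N/NC(=S)N2CCCCC2)c1` — 69.5%

All three numbers come from a functional assay on A-375 cells (Homo sapiens) for cytotoxicity, read by MTT assay, with a stated time of 72 h, tested at 3 uM; a lower number here means less inhibition of growth, a higher number more inhibition of growth at the concentration tested. Within the data shown here, compound 1 and compound 2 share a core, and the single change between them, (pyrrolidin-1-yl in place of piperidin-1-yl on a thiocarbonyl carbon), gave a number 11.9 percentage points lower from compound 1 to compound 2 (beyond the scatter). Compound 3 has the same atoms as compound 1 joined differently; the difference between the two cores is not broken down here. In this assay compound 3 and compound 1 lie within the scatter of each other, while compound 2 sits beyond the scatter below compound 3. Compound 4 `Cc1ccnc(/C(N)=N/NC(=S)N2CCCC2)c1` has not been measured. It differs from compound 3 by pyrrolidin-1-yl in place of piperidin-1-yl on a thiocarbonyl carbon, the same change seen between compound 1 and compound 2. Among the measured compounds shown here, a step of about the same size is expected, a number 12.5 percentage points lower from compound 3 to compound 4 (beyond the scatter), because the one measured example of this change gave a number 11.9 percentage points lower from compound 1 to compound 2 (beyond the scatter). Compound 4 is estimated at 57%, likely between 45% and 69%.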

Compound 4, percent growth inhibition at one concentration: 80%
Beside the measured number, compound 4's estimate is 23 percentage points below it; measured number above the stated range.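

In this assay, putting pyrrolidin-1-yl in place of piperidin-1-yl on the thiocarbonyl carbon gave a number 10.5 percentage points higher from compound 3 to compound 4 (beyond the scatter), the opposite direction to the earlier step, so the change did not carry over from one core to the other: the same change on two cores in this assay, a number 11.9 percentage points lower (beyond the scatter) from compound 1 to compound 2 and a number 10.5 percentage points higher (beyond the scatter) from compound 3 to compound 4, 22.4 percentage points apart, beyond the scatter of two such steps

For these two pairs, then, the result of this swap depends on the core that carries it, and a step measured on one core was a poor guide to the other. This does not show why the two cores part ways, or what the swap would do on a third core.

The compounds shown leave open what other groups on the thiocarbonyl carbon, such as morpholin-4-yl, azepan-1-yl or dimethylamino, would do. They also leave open whether the two cores would differ again with those groups.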